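Series notes: pyridinyl to methylphenyl exchange

The source may hold more compounds than are shown below. What is called first, only, known or untested is meant among the compounds shown, and "the series" means these compounds.

In an assay on isolated protein for inhibition of DNA topoisomerase 1 (Homo sapiens), tested at 100 uM (a lower number here means a weaker effect, a higher number a stronger effect of the compound at the concentration tested), compound 1 `Clc1ccc(-c2cc(-c3ccsc3)nc(-c3ccccc3Cl)c2)o1` gives 0% and compound 2 `Clc1ccc(-c2cc(-c3cccnc3)nc(-c3ccsc3)c2)o1` gives 0%. The step of no change at the digits printed from compound 1 to compound 2 (within the scatter) leaves compound 2 level with compound 1 at the digits shown; nothing in the series so far rises above the scatter. Compound 3 `Cc1ccc(-c2cc(-c3ccc(Cl)o3)cc(-c3ccsc3)n2)cc1` differs from compound 2 by 4-methylphenyl in place of pyridin-3-yl on an aromatic carbon. Among the measured compounds shown here, the only measured step that bears on such an exchange of one aryl group for another is the one from compound 1 to compound 2, and it brought no change. A step of no change at the digits printed from compound 2 to compound 3 (within the scatter) is therefore expected, none beyond the scatter. Compound 3 is estimated at 0%, within -10% to 12%.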

Compound 3, a percentage reported as inhibition, at one concentration (the size of the read-out at that concentration, not a potency): 2.6%
Estimate against measurement, compound 3: 2.6 percentage points below; measured number inside the range.
By their numbers in this assay, from the lowest: compounds 1, 2 and 3 (each within the scatter of the next).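

In this assay, 4-methylphenyl in place of pyridin-3-yl next to the ring nitrogen gives a number 2.6 percentage points higher from compound 2 to compound 3 (within the scatter), so a carbon-only aryl group without the hydrogen-bond acceptor leaves the read-out within the scatter. Against 2-chlorophenyl, the same group gives a number 2.6 percentage points higher from compound 1 to compound 3 (within the scatter), so all three aryl groups at this place read alike. No supporting data bear on this result.

As far as these compounds go, whether an amine or a carboxylic acid on this aryl group would give a read-out beyond the scatter in this assay remains open. The same holds for a longer chain at this position.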